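Compound 2 to compound 3: hydrogen in place of methoxy

The source may hold more compounds than are shown below. What is called first, only, known or untested is meant among the compounds shown, and "the series" means these compounds.

Measured in a functional assay on HCT-116 cells (Homo sapiens) for cytotoxicity, with a stated time of 48 h; a higher number here means a weaker inhibitor, a lower number a stronger inhibitor:
- compound 1 `COc1cc(OC)c(C(=O)/C=C/c2ccccc2SC)c(OC)c1`: 6800 nM
- compound 2 `COc1cccc(/C=C/C(=O)c2c(OC)cc(OC)cc2OC)c1`: 4300 nM

Among the compounds with values here, compound 2, at 4300 nM, has only one neighbour on these numbers, compound 1 at 6800 nM, and the two sit within the scatter of each other. The next structure is compound 3 `COc1cc(OC)c(C(=O)/C=C/c2ccccc2)c(OC)c1`, with hydrogen in place of methoxy on an aromatic carbon, meta to a large group (hydrogen in place of methoxy on an aromatic carbon). The same difference reads 3-methoxyphenyl to phenyl.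

Within the data shown here, only one measured step bears on this: a 1.6-fold lower number from compound 1 to compound 2 (0.20 log units; within the scatter). It exchanged the whole substituted phenyl group and stayed within the scatter. Among the measured compounds shown here, no measured pair shows the loss of the methoxy alone, so the evidence is thin. No direction is favoured, and no shift beyond the scatter is expected in this assay. The expected size is a 1.4-fold higher number from compound 2 to compound 3 (0.14 log units; within the scatter). For compound 3 the estimated value is 6000 nM, with an expected range from 2500 nM to 14000 nM.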

Compound 3, half-maximal inhibitory concentration: 6900 nM
Beside the measured number, compound 3's estimate is 1.2-fold (0.06 log units) below it; low and high end bracket the measured number.
By their numbers in this assay, from the lowest: compounds 2, 1 and 3 (each within the scatter of the next).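

In this assay, within the data shown here, hydrogen in place of methoxy on the 3-methoxyphenyl gives the first reading of this group on its own (a 1.6-fold higher number from compound 2 to compound 3 (0.21 log units; within the scatter)), and the step stays within the scatter. Hydrogen in place of methylsulfanyl on the 2-(methylsulfanyl)phenyl also stays within the scatter (a 1.0-fold higher number from compound 1 to compound 3 (0.01 log units; within the scatter)), so on these numbers neither substituent separates from the plain phenyl of compound 3, and all three compounds read as one level in this assay. Nothing measured here bears on why these substitutions leave the numbers within the scatter of each other, so no cause can be given.

Still open, on these data alone, is whether any group on this phenyl can move the number beyond the scatter, for example an amine, a carboxylic acid or a longer alkoxy chain in place of the methoxy. Also open, as far as these compounds go, is whether methoxy and methylsulfanyl would read alike at one shared place on the ring, since compound 1 and compound 2 differ in both the group and where it sits.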